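Methyl to (trifluoromethyl)sulfonyl on an aromatic carbon

This account rests on a few compounds, and the source may have more. Where it says the series, first, only, none or still open, it means among the compounds named here.

Of the compounds shown here, three have been measured so far in a functional assay on NCI-H146 cells (Homo sapiens) for cytotoxicity, with a stated time of 48 h, in the presence of a further agent that is not named here; on this read-out lower numbers stand for an effect already at smaller amounts and higher numbers for an effect only at larger amounts of compound. Compound 1 (`Cc1cc(S(=O)(=O)NC(=O)c2ccc(N3CCN(Cc4ccccc4-c4ccc(Cl)cc4)CC3)cc2)ccc1N[C@H](CCN(C)C)CSc1ccccc1`) has the highest number of the three at 28800 nM in this series. Compound 2 (`CN(C)CC[C@H](CSc1ccccc1)Nc1ccc(S(=O)(=O)NC(=O)c2ccc(N3CCN(CC4=C(c5ccc(Cl)cc5)CCC4)CC3)cc2)cc1[N+](=O)[O-]`) gives 691 nM and compound 3 (`CN(C)CC[C@H](CSc1ccccc1)Nc1ccc(S(=O)(=O)NC(=O)c2ccc(N3CCN(CC4=C(c5ccc(Cl)cc5)CCCCC4)CC3)cc2)cc1[N+](=O)[O-]`) gives 51.9 nM in the same read-out, and both lie lower than compound 1 by more than the scatter.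

Compound 4 (`CN(C)CC[C@H](CSc1ccccc1)Nc1ccc(S(=O)(=O)NC(=O)c2ccc(N3CCN(Cc4ccccc4-c4ccc(Cl)cc4)CC3)cc2)cc1S(=O)(=O)C(F)(F)F`) keeps the rest of compound 1 and carries (trifluoromethyl)sulfonyl in place of methyl on an aromatic carbon, ortho to a large group and meta to a large group ((trifluoromethyl)sulfonyl in place of methyl on an aromatic carbon). For the measured compounds named here, no measured pair differs in one place only, so the data hold no direct precedent for this change, and the expectation is correspondingly loose.

Going by the values given here, the values show only that much lower numbers occur, with compound 2 at 691 nM and compound 3 at 51.9 nM as the guides. On that basis, the step of a 72-fold lower number from compound 1 to compound 4 (1.86 log units; beyond the scatter) is expected to be large, beyond the scatter and towards a lower number. Compound 4 is estimated at 400 nM with an expected range of 70 nM to 3000 nM for the coming measurement.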

Compound 4, half-maximal effective concentration: 39.4 nM
Compound 4: the middle estimate sits 10-fold (1.01 log units) above what was measured; measured number outside the range, below it.
By their numbers in this assay, from the lowest: compounds 4 and 3 (each within the scatter of the next); then compound 2; then compound 1.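

In this assay, for the compounds shown here, putting (trifluoromethyl)sulfonyl in place of methyl on an aromatic carbon, ortho to a large group and meta to a large group, gives a 730-fold lower number from compound 1 to compound 4 (2.86 log units; beyond the scatter), the only step so far that isolates a single place. This place is therefore far from indifferent: with the rest of compound 1 kept, the change of this one substituent moves the read-out by a large step, well beyond the scatter. No measurement is available that bears on what lies behind the step, so it stands as a description of this one pair.

On these data alone, whether the whole (trifluoromethyl)sulfonyl group is needed remains open, as a methylsulfonyl group, a nitrile or a lone trifluoromethyl at the same carbon would separate the sulfonyl part from the fluorines. As far as these compounds go, the nitro group of compound 2 and compound 3 sits on a different remainder, so its standing against (trifluoromethyl)sulfonyl on the remainder of compound 4 also stays open.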